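A methyl on the aromatic ring of compound 3

This account rests on a few compounds, and the source may have more. Where it says the series, first, only, none or still open, it means among the compounds named here.

Three compounds have been measured in a functional assay on A549 cells (Homo sapiens) for inhibition, read by MTT assay, with a stated time of 72 h; a higher number here means a weaker inhibitor, a lower number a stronger inhibitor:

compound 1, `COc1cc2c(Oc3ccc(NC(=O)c4nn(-c5ccccc5)c(=O)cc4C)cc3F)ccnc2cc1OCCCN1CCCCC1`, gives 150 nM
compound 2, `Cc1cc(=O)n(-c2ccccc2)nc1C(=O)Nc1ccc(Oc2ccnc3cc(OCCCN4CCC(C)CC4)ccc23)c(F)c1`, gives 320 nM
compound 3, `COc1cc2c(Oc3ccc(NC(=O)c4nn(-c5ccccc5)c(=O)cc4C)cc3F)ccnc2cc1OCCCN1CCN(C)CC1`, gives 350 nM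

Compound 3 holds the highest number of the three. Its nearest neighbour is compound 2, whose value lies within the scatter of it, so no order between the two is claimed. Compound 1 lies furthest away: the step of a 2.3-fold higher number from compound 1 to compound 3 (0.37 log units; beyond the scatter) is modest but beyond the scatter, and it comes from a 4-methylpiperazin-1-yl in place of a piperidin-1-yl on the chain.

Compound 4, `COc1cc2c(Oc3ccc(NC(=O)c4nn(-c5ccccc5C)c(=O)cc4C)cc3F)ccnc2cc1OCCCN1CCN(C)CC1`, differs from compound 3 by methyl in place of hydrogen on an aromatic carbon, on a six-membered aromatic ring of carbon only, ortho to a large group; cut one bond further out the change reads phenyl to 2-methylphenyl. Within the data shown here, none of the measured steps touches this ring: the one step known, from compound 1 to compound 3, sits on the chain at the other end of the molecule, and compound 2 differs at that end too. There is therefore nothing to set a direction or size from, and the step of a 1.1-fold higher number from compound 3 to compound 4 (0.06 log units; within the scatter) is expected to stay within the scatter. Compound 4 is estimated at 400 nM, with a range from 150 nM to 1100 nM.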

Compound 4, half-maximal inhibitory concentration: 2830 nM
Compound 4: middle estimate off by 7.1-fold (0.85 log units), on the low side, outside the stated range (above it).
By their numbers in this assay, from the lowest: compound 1; then compounds 2 and 3 (each within the scatter of the next); then compound 4.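

In this assay, among these compounds, the phenyl ring, which no earlier step had touched, proves to be a place where a small change counts: going from phenyl to 2-methylphenyl gives an 8.1-fold higher number from compound 3 to compound 4 (0.91 log units; beyond the scatter). This change adds a single heavy atom, with no ring, no hydrogen-bond donors or acceptors and no net charge, yet its step is larger than the one made on the chain at the other end of the molecule, a 2.3-fold higher number from compound 1 to compound 3 (0.37 log units; beyond the scatter). Nothing available explains this rise in the number.

Going by these compounds, whether a chloro or a methoxy group at this place would give a step of similar size stays open. So does whether 2-methylphenyl would have the same effect alongside the piperidin-1-yl of compound 1.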